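The source may hold more compounds than are shown below. What is called first, only, known or untested is meant among the compounds shown, and "the series" means these compounds.

Measured in an ADME assay on HPLF cells (Homo sapiens) for cytotoxicity, with a stated time of 24 h; a higher number here means that more compound is tolerated, a lower number that less compound is tolerated:
- compound 1 `O=C1/C(=C/c2ccccc2)CCC/C1=C\c1ccccc1[N+](=O)[O-]`: 26000 nM
- compound 2 `O=C1/C(=C/c2ccc(F)cc2)CCC/C1=C\c1ccccc1[N+](=O)[O-]`: 67000 nM
- compound 3 `CN(C)c1ccc(/C=C2\CCC/C(=C\c3ccccc3[N+](=O)[O-])C2=O)cc1`: > 400000 nM, a limit and not a number

Compound 3 is the most tolerated of the three, though its position rests on a limit: the limit of > 400000 nM in this assay, at which 1 of the 3 values shown sits. Its steps are an at least 15-fold higher number from compound 1 to compound 3 (1.18 log units; beyond the scatter) and an at least 5.9-fold higher number from compound 2 to compound 3 (0.77 log units; beyond the scatter), both beyond the scatter.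

Compound 4 `COc1ccc(/C=C2\CCC/C(=C\c3ccccc3[N+](=O)[O-])C2=O)cc1` has methoxy in place of dimethylamino on an aromatic carbon, para to a large group: methoxy in place of dimethylamino on an aromatic carbon. For the measured compounds named here, no step to methoxy has been measured. The closest guides are the dimethylamino steps above, one large and one at least modest, together with a 2.6-fold higher number from compound 1 to compound 2 (0.41 log units; beyond the scatter), which is modest. Replacing dimethylamino is therefore expected to move the number down, towards compound 2 at 67000 nM, without necessarily reaching it. The expected change is an at least 3.6-fold lower number from compound 3 to compound 4 (0.56 log units; beyond the scatter), a lower number by a modest to large margin. For compound 4 the estimated value is 110000 nM, with an expected range of 40000 nM to 300000 nM.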

Compound 4, half-maximal cytotoxic concentration: 386000 nM
The estimate for compound 4 lay 3.5-fold (0.55 log units) below the measured number, outside the stated range (above it).
By their numbers in this assay, from the lowest: compound 1; then compound 2; then compound 4. At a limit, above all of these: compound 3.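

In this assay, methoxy on an aromatic carbon, para to a large group, gives a clear rise over both hydrogen and fluoro: a 15-fold higher number from compound 1 to compound 4 (1.17 log units; beyond the scatter), and a 5.8-fold higher number from compound 2 to compound 4 (0.76 log units; beyond the scatter). Against dimethylamino, the change to methoxy gives an at least 1.0-fold lower number from compound 3 to compound 4 (0.01 log units; that floor lies within the scatter). A high number at this position is therefore not confined to dimethylamino, as compound 3 and compound 4 both stand well above compound 1 and compound 2. The step from dimethylamino to methoxy gives only a floor, since compound 3 rests on a limit and not a number: the limit of > 400000 nM in this assay, at which 1 of the 4 values shown sits.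

Still open, on these data alone, is how far compound 3 lies above compound 4. Also open, as far as these compounds go, is whether a hydroxyl, a primary amine, an ethoxy group or a carboxylic acid at this position would stay with methoxy and dimethylamino or fall back towards fluoro and hydrogen.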